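The source may report more compounds than this note shows. Statements on the series, on what has been measured and on what is new or still open speak of the compounds shown alone.

Measured in a functional assay on QGY-7703 cells (Homo sapiens) for cytotoxicity, read by MTT assay, with a stated time of 24 h; on this read-out higher numbers stand for weaker inhibition and lower numbers for stronger inhibition:
- compound 1 `O=C1/C(=C/c2cccnc2)CN(S(=O)(=O)c2ccc(F)cc2)C/C1=C\c1ccccc1F` gives 15300 nM
- compound 2 `O=C1/C(=C/c2ccncc2)CNC/C1=C\c1ccccc1F` gives 14200 nM
- compound 3 `O=C1/C(=C/c2ccncc2)CN(S(=O)(=O)c2ccc(C(F)(F)F)cc2)C/C1=C\c1ccccc1F` gives 9500 nM

Compound 3, at 9500 nM, lies within the usual scatter of both compound 1 and compound 2, so the three values do not separate into a meaningful order. Compound 4 `O=C1/C(=C/c2ccncc2)CN(S(=O)(=O)c2ccc(F)cc2)C/C1=C\c1ccccc1F` is the next compound in this assay. It differs from compound 3 by fluoro in place of trifluoromethyl on an aromatic carbon, para to a large group, so that 4-(trifluoromethyl)phenyl becomes 4-fluorophenyl: fluoro in place of trifluoromethyl on an aromatic carbon.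

Among the measured compounds shown here, no pair of measured compounds differs in only one place, so this exchange has no direct precedent. The expectation rests on the narrow spread of the measured values. Compound 3 gives 9500 nM, while compound 1, which also carries 4-fluorophenyl, gives 15300 nM. No step beyond the scatter is expected, and no clear direction can be drawn from these data. The estimated change, a 1.3-fold higher number from compound 3 to compound 4 (0.10 log units; within the scatter), is expected to stay within the scatter. The estimate for compound 4 is 12000 nM, with an expected range from 6000 nM to 24000 nM.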

Compound 4, half-maximal inhibitory concentration: 9100 nM
Compound 4: middle estimate off by 1.3-fold (0.12 log units), on the high side; the measured number falls inside the stated range.
By their numbers in this assay, from the lowest: compounds 4, 3, 2 and 1 (each within the scatter of the next).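

In this assay, among the compounds shown here, fluoro in place of trifluoromethyl on an aromatic carbon gives a 1.0-fold lower number from compound 3 to compound 4 (0.02 log units; within the scatter) and provides the first single-place reading at this position, where the exchange has no effect that can be separated from the scatter. The two other single-place readings are also within the scatter: (4-fluorophenyl)sulfonyl in place of hydrogen on the ring amine nitrogen gives a 1.6-fold lower number from compound 2 to compound 4 (0.19 log units; within the scatter) and pyridin-4-yl in place of pyridin-3-yl on the double-bonded chain carbon gives a 1.7-fold lower number from compound 1 to compound 4 (0.23 log units; within the scatter) so neither exchange separates these compounds in this cytotoxicity read-out. No supporting evidence is available to explain these results.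

Still open, from the compounds shown here alone, is whether a methoxy, an amine or a carboxylic acid on the same aromatic carbon would give a step beyond the scatter from compound 4. Also open is whether replacing the 2-fluorophenyl group or the pyridin-4-yl group with a different ring, such as a thiophene or an imidazole, would separate any analogue from compound 4 in this assay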